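Lengthening a Hydroxyl Chain: One Change on Two Cores

The source may hold more compounds than are shown below. What is called first, only, known or untested is meant among the compounds shown, and "the series" means these compounds.

Compound 1 `CCCn1c(=O)n(CCO)c(=O)c2[nH]cnc21` and compound 2 `CCCn1c(=O)n(CCCO)c(=O)c2[nH]cnc21` share a core and differ in one place: hydroxymethyl in place of hydroxy on a saturated chain carbon, two bonds along the chain from an aromatic nitrogen. In a functional assay (trachea) with Cavia porcellus as the target (a lower number here means that less compound is needed, a higher number that more compound is needed for the effect), compound 1 gives 510 nM, and compound 2 gives 5100 nM; this is a 10-fold higher number from compound 1 to compound 2 (1.00 log units; beyond the scatter). Compound 3 `CCCn1c(=O)n(C)c(=O)c2c1ncn2CCO` carries its groups on another arrangement of the core, and the difference between the two cores is not broken down here. In this assay compound 3 gives 31800 nM, the highest of the three numbers. Compound 4 `CCCn1c(=O)n(C)c(=O)c2c1ncn2CCCO` stands to compound 3 as compound 2 stands to compound 1: hydroxymethyl in place of hydroxy on a saturated chain carbon, two bonds along the chain from an aromatic nitrogen. Because the same change gave a 10-fold higher number from compound 1 to compound 2 (1.00 log units; beyond the scatter), a step of similar size is expected, namely a 6.3-fold higher number from compound 3 to compound 4 (0.80 log units; beyond the scatter), though this rests on a single pair. Compound 4 is thus expected to give 200000 nM in this assay, estimated between 60000 nM and 600000 nM.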

Compound 4, half-maximal effective concentration: 22600 nM
Estimate against measurement, compound 4: 8.8-fold (0.95 log units) above; measured number outside the range, below it.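

In this assay, the step seen on the first core does not carry over to the second, where the same change gives a 1.4-fold lower number from compound 3 to compound 4 (0.15 log units; within the scatter). Set side by side, the two steps show that the outcome of this change depends on the core: the same change on two cores in this assay, a 10-fold higher number (1.00 log units; beyond the scatter) from compound 1 to compound 2 and a 1.4-fold lower number (0.15 log units; within the scatter) from compound 3 to compound 4, 14-fold (1.15 log units) apart, beyond the scatter of two such steps. Among these compounds, this rests on only two pairs, so it does not show why the cores differ or how the change would behave on a further core.

Still open, as far as these compounds go, is whether a longer chain, such as 4-hydroxybutyl, would raise the number on either core. From the compounds shown here alone, it is equally open whether an amine in place of the hydroxy would follow the same course.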